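This account rests on a few compounds, and the source may have more. Where it says the series, first, only, none or still open, it means among the compounds named here.

Measured so far:
compound 1, `COc1ccc2c(c1)c(CCCC(=O)N1CCOCC1)c(C)n2Cc1ccc(C)cc1`: 26.4%
compound 2, `Cc1c(CCCC(=O)N2CCOCC2)c2cc(Cl)ccc2n1Cc1ccc(Cl)cc1`: 37.9%

Both compounds were tested in an assay on cells for inhibition of Polyunsaturated fatty acid 5-lipoxygenase (Rattus norvegicus), tested at 5 uM; on this read-out lower numbers stand for less inhibition and higher numbers for more inhibition at the one concentration tested (going by the name of the read-out). Compound 1 gives 26.4% and stands lowest of the two numbers; compound 2 gives 37.9%, a number higher by a margin beyond the usual scatter of such measurements. For the measured compounds named here, no step between compounds differing in a single place has been measured, so there is no measured pairwise step to lean on.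

Compound 3, `COc1ccc2[nH]c(C)c(CCCC(=O)N3CCOCC3)c2c1`, has not yet been measured in this assay. It differs from compound 1 in one place: hydrogen in place of 4-methylbenzyl on an aromatic nitrogen. Nothing in the measured compounds tells how the core behaves once the aromatic nitrogen carries only hydrogen, so the size of the step is a guess. The expectation is a downward step from compound 1 to compound 3, a number 12.4 percentage points lower from compound 1 to compound 3 (beyond the scatter), of a size beyond the scatter. For compound 3 the estimated inhibition in this assay is 14%, with a range from 0% to 32%.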

Compound 3, a percentage reported as inhibition, at one concentration (the size of the read-out at that concentration, not a potency): 72.9%
Estimate against measurement, compound 3: 58.9 percentage points below; measured number above the stated range.
By their numbers in this assay, from the lowest: compound 1; then compound 2; then compound 3.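

In this assay, for the compounds shown here, hydrogen in place of 4-methylbenzyl on the aromatic nitrogen gives a large change, a number 46.5 percentage points higher from compound 1 to compound 3 (beyond the scatter), the first single-place step. On the core of compound 1, then, the 4-methylbenzyl group is not required for inhibition at the one concentration tested, and this position strongly affects the read-out. No measurement at hand accounts for the size of this step.

As far as these compounds go, whether a group of intermediate size on this nitrogen, such as methyl or unsubstituted benzyl, gives a number nearer compound 1 or compound 3 remains open, as does the effect of an acetic acid chain there. Also open, from the compounds shown here alone, is whether hydrogen on the aromatic nitrogen brings a similar step on the core of compound 2.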